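Antiproliferative activity on HS27 cells: an amide-to-urea change

A few compounds are considered here, and "the series" means these few. Any claim that something is new, unique, unknown or untested is made for them only; others in the source may bear on it.

Measured compounds:
compound 1 `O=C(Nc1ccc(-n2ccc3c(NC(=O)c4ccccc4)ncnc32)cc1)c1ccc(Cl)c(Cl)c1`: 5000 nM
compound 2 `Cc1cn(-c2cc(C(=O)Nc3ccc(-n4ccc5c(NC(=O)c6ccccc6)ncnc54)cc3)cc(C(F)(F)F)c2)cn1`: 2800 nM
compound 3 `CC(=O)Nc1ncnc2c1ccn2-c1ccc(NC(=O)c2ccc(Cl)c(C(F)(F)F)c2)cc1`: > 10000 nM

Of the compounds shown here, three built on a shared core have been tested in an ADME assay on HS27 cells (Homo sapiens) for antiproliferative activity, read by MTT assay, with a stated time of 24 h; on this read-out lower numbers stand for stronger inhibition and higher numbers for weaker inhibition. Compound 1 gives 5000 nM in this assay. Compound 2 gives 2800 nM, and the two numbers lie within the scatter of each other, so neither can be called the more active. Compound 3 reports only > 10000 nM, which is a limit of this assay rather than a number, the situation described by the limit of > 10000 nM in this assay, at which 1 of the 3 values shown sits. Among the two numbers shown, compound 1 thus stands at the higher end.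

The next compound, compound 4 `O=C(Nc1ccc(-n2ccc3c(NC(=O)c4ccccc4)ncnc32)cc1)Nc1ccc(Cl)c(C(F)(F)F)c1`, has not yet been measured. It differs from compound 1 in one place: (4-chloro-3-(trifluoromethyl)phenyl)amino in place of 3,4-dichlorophenyl on a carbonyl carbon. The added group brings one hydrogen-bond donor, as counted in that difference.

For the measured compounds named here, no measured pair shows what such a change does here, and compound 3, the only measured compound carrying a 4-chloro-3-(trifluoromethyl)phenyl group, also carries an acetyl in place of a benzoyl, so it gives no clean guide. With so few numbers, the expectation is a step of a 1.2-fold higher number from compound 1 to compound 4 (0.08 log units; within the scatter), which is not beyond the scatter. Compound 4 is therefore estimated at 6000 nM in this assay, with a range from 2500 nM to 15000 nM.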

Compound 4, half-maximal inhibitory concentration: 6000 nM
Compound 4: middle estimate and measured number agree at the digits printed; measured number inside the range.
By their numbers in this assay, from the lowest: compounds 2, 1 and 4 (each within the scatter of the next, the first and the last beyond it). At a limit, above all of these: compound 3.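

For the compounds shown here, the first step that can be read at this place, a carbonyl carbon whose other neighbour is an amide-type nitrogen, is a 1.2-fold higher number from compound 1 to compound 4 (0.08 log units; within the scatter) in this assay. Here, an amide becomes a urea as (4-chloro-3-(trifluoromethyl)phenyl)amino takes the place of 3,4-dichlorophenyl, bringing more heavy atoms and one hydrogen-bond donor, yet compound 1 and compound 4 cannot be told apart in this read-out. No measurement shown here offers an explanation for this result.

This single pair changes the nitrogen link and the groups on the ring at the same time, so it cannot say what each contributes, and only a compound with a 3,4-dichlorophenylamino group on the same carbonyl carbon could begin to separate the two. It also leaves open whether the same place would accept something quite different, such as a morpholine, a carboxylic acid or a plain alkyl chain, in place of the substituted aromatic ring.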